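Oxazolidinone series: acetoxy to methanesulfonamido on the side chain

The compounds below may be only part of what the source reports. "The series", "measured", "known", "first", "only" and "open" are said of these compounds alone.

Working notes on the series. Compound 1 `O=C1O[C@@H](CN2CCCCC2)CN1c1ccc(-n2cc(-c3ccccn3)cn2)c(F)c1` gives 3.1 in a physicochemical assay for lipophilicity, read by HPLC, measured as octanol-water partition; on this read-out lower numbers stand for lower lipophilicity and higher numbers for higher lipophilicity. Compound 2 `O=C1O[C@@H](CN2CCC(c3ccc(F)cc3)CC2)CN1c1ccc(-n2cc(-c3ccccn3)cn2)c(F)c1` gives 5.78 in this assay, the change between them being a number 2.68 log units higher from compound 1 to compound 2 (beyond the scatter). Compound 3 `CC(=O)OC[C@H]1CN(c2ccc(-n3cc(-c4ccccn4)cn3)c(F)c2)C(=O)O1` gives 2.09 in this assay, with a number 1.01 log units lower from compound 1 to compound 3 (beyond the scatter). Compound 3 therefore stands lowest of the three numbers, compound 1 being the nearest and compound 2 the furthest.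

Compound 4 `CS(=O)(=O)NC[C@H]1CN(c2ccc(-n3cc(-c4ccccn4)cn3)c(F)c2)C(=O)O1` remains to be measured. It differs from compound 3 in one place: methanesulfonamido in place of acetoxy on a saturated chain carbon bound to a saturated ring carbon. Neither measured step contains a methanesulfonamido group, so no step bears directly on this exchange; the two steps shown only mark how far a change on this side chain has moved the read-out in this assay, one of them large upward with 4-fluorophenyl and one large downward with acetoxy in place of piperidin-1-yl. The entering group carries one hydrogen-bond donor where the leaving group carries none, and the expectation is a step downward beyond the scatter, smaller than either measured step. Compound 4 is expected to give 1.3 in this assay, in the range 0.7 to 1.9. The expected step is a number 0.79 log units lower from compound 3 to compound 4 (beyond the scatter).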

Compound 4, partition coefficient: 1.38
The estimate for compound 4 lay 0.08 log units below the measured number; the range from low to high includes it.
By their numbers in this assay, from the lowest: compound 4; then compound 3; then compound 1; then compound 2.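

In this assay, going by these compounds alone, this position on the saturated chain carbon bound to a saturated ring carbon now shows a step between two groups without a ring: methanesulfonamido in place of acetoxy gives a number 0.71 log units lower from compound 3 to compound 4 (beyond the scatter) and so is modest, whereas the earlier steps at this place started from piperidin-1-yl. Measured from that same starting point, methanesulfonamido gives a number 1.72 log units lower from compound 1 to compound 4 (beyond the scatter) and acetoxy gives a number 1.01 log units lower from compound 1 to compound 3 (beyond the scatter), so the read-out at this position reaches further down than acetoxy had shown. No supporting evidence is available on what sets the size of the step from acetoxy to methanesulfonamido.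

The compounds shown leave open how much of that step goes with the amide hydrogen and how much with the sulfonyl: acetamido on the same carbon would pair that hydrogen with a carbonyl, and methyl(methanesulfonyl)amino would keep the sulfonyl without it. Also open, from the compounds shown here alone, is how the read-out at this position responds to a primary amine, a carboxylic acid or a longer chain such as ethanesulfonamido.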